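From Ethyl to Methyl: Compound 1 and Compound 4

The source may report more compounds than this note shows. Statements on the series, on what has been measured and on what is new or still open speak of the compounds shown alone.

In a functional assay on the whole organism with Mus musculus as the target, in the rotarod test (on this read-out higher numbers stand for an effect only at larger amounts of compound and lower numbers for an effect already at smaller amounts), compound 1 (`CCN(C)C(=O)/C=C1\CCc2c(F)cc(F)cc21`) gives 73 mg/kg while compound 2 (`C/C(=C\C(=O)NC1CC1)c1cccc(F)c1`) gives 71 mg/kg and compound 3 (`Cc1cccc2c1CC/C2=C\C(=O)NC1CC1`) gives 64 mg/kg so that compound 1 stands level with both, all three lying within the usual scatter. Compound 4 (`CN(C)C(=O)/C=C1\CCc2c(F)cc(F)cc21`) keeps the core of compound 1 and differs from it in one place by hydrogen in place of methyl on a saturated chain carbon bound to an amide-type nitrogen with hydrogen in place of methyl on a saturated chain carbon bound to an amide-type nitrogen, which takes ethyl to methyl. Among the compounds with values here, no measured pair shows this change, so in this assay no step beyond the scatter is expected in either direction. The expected step is a 1.0-fold lower number from compound 1 to compound 4 (0.02 log units; within the scatter) and no more. Compound 4 is estimated at 70 mg/kg with a range from 38 mg/kg to 130 mg/kg around that value.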

Compound 4, dose for half-maximal effect: 100 mg/kg
Compound 4: middle estimate off by 1.4-fold (0.15 log units), on the low side; the range from low to high includes it.
By their numbers in this assay, from the lowest: compounds 3, 2, 1 and 4 (each within the scatter of the next).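

In this assay, within the data shown here, the first measured pair at this position gives a 1.4-fold higher number from compound 1 to compound 4 (0.14 log units; within the scatter). Ethyl to methyl on this amide-type nitrogen, which turns ethyl(methyl)carbamoyl into dimethylcarbamoyl, therefore produces no step beyond the scatter on the core of compound 1. No measurement on hand accounts for this result. The compounds shown leave open whether a longer chain such as butyl on this nitrogen would also stay within the scatter. They also leave open how an amine or a carboxylic acid at the end of such a chain would read.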